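Naphthalenesulfonamide series, neuropeptide Y receptor type 1 binding

The source may report more compounds than this note shows. Statements on the series, on what has been measured and on what is new or still open speak of the compounds shown alone.

Measured compounds:
- compound 1, `O=S(=O)(NCCCCCCNCc1ccc2ccccc2c1)c1ccc2ccccc2c1`, 7300 nM
- compound 2, `O=S(=O)(NC[C@H]1CC[C@H](CNCC2CCc3ccccc3C2)CC1)c1ccc2ccccc2c1`, 5550 nM

Of the compounds shown here, two have been measured in an assay on COS-7 cells for binding affinity to Neuropeptide Y receptor type 1 (Homo sapiens), read by radioligand binding; a lower number here means a stronger inhibitor, a higher number a weaker inhibitor. Compound 1 gives 7300 nM, and compound 2 gives 5550 nM. Going by the values given here, the two values lie within the scatter of each other, so compound 2 stands level with compound 1 rather than apart from it; no step between them can be read.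

Compound 3, `Nc1ccccc1S(=O)(=O)NC[C@H]1CC[C@H](CNCC2CCc3ccccc3C2)CC1`, is not yet measured. It differs from compound 2 in one place: 2-aminophenyl in place of naphthalen-2-yl on a sulfonyl sulfur. Among the compounds with values here, no step of this kind has been measured, so there is nothing to set the size of the change against. Compound 3 keeps the whole remaining frame of compound 2 and changes only the group on the sulfonyl sulfur. The expectation for compound 3 in this assay is 12000 nM, within 4000 nM to 40000 nM. The step from compound 2 to compound 3 is expected to be a 2.2-fold higher number from compound 2 to compound 3 (0.33 log units; beyond the scatter), a weakening that may be only modestly beyond the scatter.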

Compound 3, inhibition constant: 17200 nM
Compound 3: middle estimate off by 1.4-fold (0.16 log units), on the low side, within the range that was stated.
By their numbers in this assay, from the lowest: compounds 2 and 1 (each within the scatter of the next); then compound 3.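

The group on the sulfonyl sulfur now has its first measured step, and in this assay this position is not indifferent to the change: 2-aminophenyl in place of naphthalen-2-yl gives a 3.1-fold higher number from compound 2 to compound 3 (0.49 log units; beyond the scatter). The exchange removes one of the two six-membered aromatic rings and brings in a hydrogen-bond donor and acceptor in the same step, so the result belongs to the whole exchange and not to either part alone. Nothing measured here explains the weakening.

As far as these compounds go, whether it follows the loss of the second ring or the arrival of the amino group remains open; a plain phenyl group on the sulfonyl sulfur would separate the two. Also open, from the compounds shown here alone, is whether the same exchange gives a similar step on the frame of compound 1.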